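This account rests on a few compounds, and the source may have more. Where it says the series, first, only, none or still open, it means among the compounds named here.

Measured compounds:
compound 1 `CCOc1ccc(NC(=O)Nc2cc(C(C)(C)C)nn2-c2ccccc2)cc1` — 1.1 degrees C
compound 2 `CC(C)(C)c1cc(NC(=O)Nc2cc(C(F)(F)F)cc(C(F)(F)F)c2)n(-c2ccccc2)n1` — 0 degrees C
compound 3 `CC(C)(C)c1cc(NC(=O)Nc2cc(C(F)(F)F)cc(C(F)(F)F)c2)n(-c2ccc(F)cc2)n1` — 0.5 degrees C

In an assay on isolated protein for inhibition of STE20-like serine/threonine-protein kinase (Homo sapiens), read by thermal shift assay, tested at 10 uM (a higher number here means that the compound stabilises the target more against heat, a lower number that the compound stabilises the target less), compound 1 gives the largest of the three numbers; its gap to compound 3 is within the scatter, while its gap to compound 2 is beyond it. Within the data shown here, the only step between measured compounds, a number 0.50 degrees C higher from compound 2 to compound 3 (within the scatter), lies elsewhere on the core and does not touch the place changed here. Compound 4 `CC(C)(C)c1cc(NC(=O)Nc2cc(F)cc(F)c2)n(-c2ccccc2)n1` carries 3,5-difluorophenyl in place of 4-ethoxyphenyl on an amide-type nitrogen. Among the measured compounds shown here, no measured step covers this change; compounds 1 and 2, which differ at the same place, show a gap beyond the scatter, but no step is given for that pair. On the strength of that gap, a drop is expected, estimated as a number 0.60 degrees C lower from compound 1 to compound 4 (within the scatter). Compound 4 is therefore expected to give 0.5 degrees C, with a range from -0.5 degrees C to 1.5 degrees C.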

Compound 4, shift of the target's melting temperature: 3 degrees C
Compound 4: middle estimate off by 2.5 degrees C, on the low side, and the stated range ends below it.
By their numbers in this assay, from the lowest: compounds 2, 3 and 1 (each within the scatter of the next, the first and the last beyond it); then compound 4.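

Putting 3,5-difluorophenyl in place of 4-ethoxyphenyl on the amide-type nitrogen gives a number 1.9 degrees C higher from compound 1 to compound 4 (beyond the scatter) in this assay and shows that this place can raise the number as well as lower it. The aryl group's substituents decide the direction here: compound 2, with two trifluoromethyl groups, gives 0 degrees C and compound 4 gives 3 degrees C on the same core. No available evidence explains the rise.
As far as these compounds go, whether chloro or methoxy in place of the fluoro groups keeps this gain stays open. So does whether the change carries over to the 4-fluorophenyl core of compound 3.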